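The source may hold more compounds than are shown below. What is called first, only, known or untested is meant among the compounds shown, and "the series" means these compounds.

Measured in a functional assay on CEM-DNR-bulk cells (Homo sapiens), read by MTT assay, with a stated time of 72 h; a higher number here means a weaker inhibitor, a lower number a stronger inhibitor:
compound 1 `CN(C)c1ncnc2c1c(-c1ccoc1)cn2[C@@H]1O[C@H](CO)[C@@H](O)[C@H]1O`: > 20000 nM (a limit)
compound 2 `CN(C)c1ncnc2c1c(-c1cc3ccccc3o1)cn2[C@@H]1O[C@H](CO)[C@@H](O)[C@H]1O`: > 20000 nM (a limit)

Compound 2 stands at a limit and has no numerical value: in this assay it reads > 20000 nM. The same holds across the short series: the limit of > 20000 nM in this assay, at which 2 of the 2 values shown sit. Among the measured compounds shown here, the only measured step is a step that the two limits leave unreadable from compound 1 to compound 2, so it offers no size to carry forward.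

Compound 3 `C#Cc1cn([C@@H]2O[C@H](CO)[C@@H](O)[C@H]2O)c2ncnc(N(C)C)c12` carries ethynyl in place of 1-benzofuran-2-yl on an aromatic carbon, on the otherwise shared core: ethynyl in place of 1-benzofuran-2-yl on an aromatic carbon. For the measured compounds named here, no measured step covers this exchange, and neither group on compound 1 or compound 2 resembles ethynyl in the counts given, so the series offers only weak guidance. The expectation is that compound 3 stays close to the limit in this assay, with a real chance that it gives only a limit again, though a measurable number cannot be ruled out. The expected change is an at least 1.3-fold lower number from compound 2 to compound 3 (0.12 log units; that floor lies within the scatter). For compound 3 the estimated value is 15000 nM, with an expected range from 3000 nM to 30000 nM.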

Compound 3, half-maximal inhibitory concentration: 240 nM
The estimate for compound 3 lay 63-fold (1.80 log units) above the measured number; measured number outside the range, below it.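

In this assay, ethynyl in place of 1-benzofuran-2-yl on an aromatic carbon gives an at least 83-fold lower number from compound 2 to compound 3 (1.92 log units; beyond the scatter), and ethynyl in place of furan-3-yl on the same carbon gives an at least 83-fold lower number from compound 1 to compound 3 (1.92 log units; beyond the scatter). Compound 1 and compound 2 are limits and not numbers, so both steps are floors and the step between those two compounds cannot be read: the limit of > 20000 nM in this assay, at which 2 of the 3 values shown sit. This aromatic carbon of the five-membered ring is therefore not closed to a measurable number in this assay, as the earlier pair alone left possible, and among the three compounds shown only the one with ethynyl, which has no ring and a triple bond, leaves the limit.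

The compounds shown do not separate the loss of the aromatic ring groups from the entry of the triple bond, as both come in a single exchange. As far as these compounds go, whether the number depends on the triple bond itself remains open, and methyl, ethyl or vinyl at this carbon, or a longer chain such as prop-1-ynyl, would bear on that question.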